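The source may hold more compounds than are shown below. What is called first, only, known or untested is meant among the compounds shown, and "the series" means these compounds.

Compound 1 `CCOc1ccc(/C=C(\C(=O)c2ccc(Cl)cc2)S(=O)(=O)Cc2ccc(F)cc2)cc1OC`: 50000 nM
Compound 2 `CCOc1ccc(/C=C(\C(=O)c2ccc(Cl)cc2)S(=O)(=O)Cc2ccc(C)cc2)cc1OC`: 10000 nM
Compound 3 `CCOc1ccc(/C=C(/Sc2ccc(C)cc2)C(=O)c2ccc(Cl)cc2)cc1OC`: 25000 nM

All three values come from a functional assay on DU-145 cells (Homo sapiens) for inhibition, read by trypan blue exclusion, with a stated time of 96 h; a higher number here means a weaker inhibitor of growth, a lower number a stronger inhibitor of growth. Compound 3, at 25000 nM, cannot be separated from its nearest neighbour, since the gap is a 2.0-fold lower number from compound 1 to compound 3 (0.30 log units; within the scatter). It does stand clear of the lowest number, with a gap of a 2.5-fold higher number from compound 2 to compound 3 (0.40 log units; beyond the scatter).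

Compound 4 `CCOc1ccc(/C=C(/SCc2ccc(Cl)c(Cl)c2)C(=O)c2ccc(Cl)cc2)cc1OC` has not yet been measured. It carries 3,4-dichlorobenzyl in place of 4-methylphenyl on a sulfur.

For the measured compounds named here, no measured pair makes this exact change, so the evidence is indirect. A swap on the aromatic ring alone gave a 5.0-fold lower number from compound 1 to compound 2 (0.70 log units; beyond the scatter), which shows that such a swap can move the number by a modest amount. Compound 2 also has a benzyl group on its sulfur and sits at 10000 nM, which hints that a benzyl group may favour a lower number. Compound 1 goes against this hint, as it has a benzyl group too yet sits at 50000 nM.

A modest move towards a lower number in this assay is therefore expected, though with little certainty, and the expected step is a 2.5-fold lower number from compound 3 to compound 4 (0.40 log units; beyond the scatter). Compound 4 is estimated at 10000 nM, with an expected range of 2500 nM to 40000 nM.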

Compound 4, concentration for 50% growth inhibition: 25000 nM
For compound 4 the middle estimate is 2.5-fold (0.40 log units) below the measured one, within the range that was stated.
By their numbers in this assay, from the lowest: compound 2; then compounds 3, 4 and 1 (each within the scatter of the next).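

In this assay, putting 3,4-dichlorobenzyl in place of 4-methylphenyl on the sulfur gives no change at the digits printed from compound 3 to compound 4 (within the scatter), so on this series a group of 9 heavy atoms, two of them chlorine, reads the same as one of 7 carbon atoms. Compound 4 also sits where compound 3 sits relative to the two sulfonyl compounds: it stands clear of compound 2 (a 2.5-fold higher number from compound 2 to compound 4 (0.40 log units; beyond the scatter)) but cannot be separated from compound 1 (a 2.0-fold lower number from compound 1 to compound 4 (0.30 log units; within the scatter)), which leaves compound 2 alone at the lowest number of the four. Nothing available here explains why this swap left the number in place.

Going by these compounds, this single step swaps the ring's substituents and also adds a benzyl carbon, so the share of each part stays open, including whether opposing contributions cancel in compound 4. Also open, on these data alone, is how a different kind of group on this sulfur would read, such as a longer chain ending in an amine or a carboxylic acid.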